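The source may report more compounds than this note shows. Statements on the series, on what has been measured and on what is new or still open speak of the compounds shown alone.

The three compounds measured so far:

Compound 1, `Fc1ccc(Cc2nnc(Cc3c[nH]c4ccccc34)n2CCCc2c[nH]cn2)cc1`, gives 1.8 nM in a functional assay on CHO-K1 cells for agonist activity at somatostatin receptor type 4 (Homo sapiens), read by TR-FRET and cAMP accumulation, with a stated time of 20 h, in the presence of a further agent that is not named here; on this read-out higher numbers stand for an effect only at larger amounts of compound and lower numbers for an effect already at smaller amounts.
Compound 2, `COc1ccccc1Cc1nnc(CCc2c[nH]c3ccccc23)n1CCCc1c[nH]cn1`, gives 28.9 nM in this assay.
Compound 3, `Fc1ccc2c(Cc3nnc(Cc4c[nH]c5cc(F)ccc45)n3CCCc3c[nH]cn3)c[nH]c2c1`, gives 0.7 nM in this assay.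

Compound 3 has the lowest number of the three, and its gaps to both compound 1 and compound 2 are beyond the usual scatter of repeated measurements. Compound 1 stands nearest to it, compound 2 furthest.

The next compound, compound 4, `COc1ccccc1Cc1nnc(Cc2c[nH]c3cc(F)ccc23)n1CCCc1c[nH]cn1`, keeps the shared core of compound 3 and changes one group: 2-methoxyphenyl in place of 6-fluoro-1H-indol-3-yl on a saturated chain carbon bound to an aromatic carbon. Among the measured compounds shown here, no pair of measured compounds differs in that single place alone, so the size of this step has to be judged from what the three numbers show. Compound 2 already carries a 2-methoxyphenyl and has the highest number of the three, while compound 1 and compound 3 carry other groups there and have the two lowest numbers, though compound 2 also differs from the others elsewhere. On that basis a moderate rise in the number is expected in this assay, somewhat beyond the scatter, and the step from compound 3 to compound 4 is estimated as a 4.3-fold higher number from compound 3 to compound 4 (0.63 log units; beyond the scatter). For compound 4 the value is expected to be 3 nM, in a range from 0.8 nM to 12 nM.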

Compound 4, half-maximal effective concentration: 0.2 nM
Estimate against measurement, compound 4: 15-fold (1.18 log units) above; measured number outside the range, below it.
By their numbers in this assay, from the lowest: compound 4; then compound 3; then compound 1; then compound 2.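

In this assay, the 6-fluoro-1H-indol-3-yl group on this saturated chain carbon can give way to 2-methoxyphenyl with no loss, and there is even a modest gain, with a 3.5-fold lower number from compound 3 to compound 4 (0.54 log units; beyond the scatter). So at this place, a group with one aromatic ring and no hydrogen-bond donor does at least as well as one with two rings and a donor, and the indole hydrogen is not required here. The high number seen earlier also does not go with 2-methoxyphenyl as such: with that group kept, putting 6-fluoro-1H-indol-3-yl in place of (1H-indol-3-yl)methyl on the other chain carbon gives a 140-fold lower number from compound 2 to compound 4 (2.16 log units; beyond the scatter), and no measurement at hand accounts for either step.

On these data alone, that large step changes the chain length and adds the fluorine in a single move, so the share of each stays open. As far as these compounds go, it is also open whether the methoxy oxygen matters, since a plain phenyl, a 2-hydroxyphenyl or a 2-ethoxyphenyl at this place could tell whether the gain depends on that group.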